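Chloro in Place of Hydroxy: Expecting Compound 4

A few compounds are considered here, and "the series" means these few. Any claim that something is new, unique, unknown or untested is made for them only; others in the source may bear on it.

Three measured compounds share one core and differ only at a single oxygen on the aromatic ring. Compound 1 `CCOc1ccc2oc(/C=C/[S+](C)[O-])cc(=O)c2c1` gives 1500 nM in a functional assay on A549 cells (Homo sapiens) for cytotoxicity, with a stated time of 48 h; a lower number here means a stronger inhibitor, a higher number a weaker inhibitor. Compound 2 `CCCC(=O)Oc1ccc2oc(/C=C/[S+](C)[O-])cc(=O)c2c1` gives 2200 nM in this assay, and compound 3 `C[S+]([O-])/C=C/c1cc(=O)c2cc(O)ccc2o1` gives 10500 nM. Compound 3 therefore holds the highest number of the three: a 7.0-fold higher number from compound 1 to compound 3 (0.85 log units; beyond the scatter) and a 4.8-fold higher number from compound 2 to compound 3 (0.68 log units; beyond the scatter) both lie beyond the scatter, while a 1.5-fold higher number from compound 1 to compound 2 (0.17 log units; within the scatter) stays within it.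

Compound 4 `C[S+]([O-])/C=C/c1cc(=O)c2cc(Cl)ccc2o1` remains unmeasured. Against compound 3 it shows (chloro in place of hydroxy on an aromatic carbon). For the measured compounds named here, no measured step exchanges the oxygen itself; each keeps it and varies what sits on it, so they bear on this change only loosely. Still, because a 7.0-fold higher number from compound 1 to compound 3 (0.85 log units; beyond the scatter) and a 4.8-fold higher number from compound 2 to compound 3 (0.68 log units; beyond the scatter) both place the hydroxy compound highest, a change that removes the hydroxy is expected to lower the number toward the other two rather than raise it further, with wide uncertainty.

Compound 4 is expected near 4000 nM, between 1500 nM and 12000 nM, meaning an expected 2.6-fold lower number from compound 3 to compound 4 (0.42 log units; beyond the scatter).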

Compound 4, half-maximal inhibitory concentration: 1700 nM
For compound 4 the middle estimate is 2.4-fold (0.37 log units) above the measured one; measured number inside the range.
By their numbers in this assay, from the lowest: compounds 1, 4 and 2 (each within the scatter of the next); then compound 3.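

Chloro in place of hydroxy on this aromatic carbon gives a 6.2-fold lower number from compound 3 to compound 4 (0.79 log units; beyond the scatter) in this assay, so the oxygen itself can be lost without the number staying high, something the earlier steps could not show while they kept that oxygen. Chloro also cannot be told apart from the groups that keep an oxygen here: a 1.3-fold lower number from compound 2 to compound 4 (0.11 log units; within the scatter) and a 1.1-fold higher number from compound 1 to compound 4 (0.05 log units; within the scatter) both lie within the scatter, which leaves compound 3 alone with the free hydroxy and the highest number. No evidence is available on why the free hydroxy stands apart.

On these data alone, whether an amine or a carboxylic acid on this carbon would fall with compound 3 or with the other three remains open. The same holds for fluoro or methyl in place of chloro, and for this exchange elsewhere on the shared core.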